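Microsomal stability notes: fluoro to methyl swap

The source may hold more compounds than are shown below. What is called first, only, known or untested is meant among the compounds shown, and "the series" means these compounds.

Measured compounds in an ADME assay on microsomes from liver (Rattus norvegicus) for metabolic stability, read by LC-MS, using NADPH, with a stated time of 10 min, tested at 0.5 uM; a lower number here means that less of the compound is left, a higher number that more of the compound is left:
- compound 1, `CC(=O)Nc1cc(-c2ccc(OC[C@@H](N)CC(C)C)c(F)c2)ccn1`: compound 1 gives 80%
- compound 2, `COC(=O)Nc1cc(-c2ccc(OC[C@@](C)(N)CC(C)C)c(C)c2)ccn1`: compound 2 gives 96%
- compound 3, `COC(=O)Nc1cc(-c2ccc(OC[C@@](C)(N)CC(C)C)c(F)c2)ccn1`: compound 3 gives 94%

Compound 1 has the lowest number of the three; its gaps to compound 3 and to compound 2 are both beyond the scatter. The difference between the core of compound 1 and the core of compound 3 is not broken down here.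

Within the core of compound 3, the change methyl in place of fluoro on an aromatic carbon gave a number 2 percentage points higher from compound 3 to compound 2 (within the scatter).

Compound 4, `CC(=O)Nc1cc(-c2ccc(OC[C@@H](N)CC(C)C)c(C)c2)ccn1`, is not yet measured. It arises from compound 1 by methyl in place of fluoro on an aromatic carbon. The surroundings are not identical: in the measured pair the place is ortho to a (2-amino-2,4-dimethylpentyl)oxy group, in the new pair ortho to a (2-amino-4-methylpentyl)oxy group, so this is the same kind of change, not the same change.

For compound 4 a step of a number 2 percentage points higher from compound 1 to compound 4 (within the scatter) is expected, resting on the near-flat a number 2 percentage points higher from compound 3 to compound 2 (within the scatter). Compound 4 is therefore estimated at 82%, with an expected range from 70% to 93%.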

Compound 4, percent of the compound remaining: 99%
For compound 4 the middle estimate is 17 percentage points below the measured one, outside the stated range (above it).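

In this assay, methyl in place of fluoro on an aromatic carbon gave a number 19 percentage points higher from compound 1 to compound 4 (beyond the scatter), and the size of this step did not carry over between the two cores: the same change on two cores in this assay, a number 2 percentage points higher (within the scatter) from compound 3 to compound 2 and a number 19 percentage points higher (beyond the scatter) from compound 1 to compound 4, 17 percentage points apart, beyond the scatter of two such steps

A step read on one core is therefore a poor guide to the size of the same change on the other core in this series. The two pairs do not show which difference between the cores goes with the gap, and compound 3 already gives 94%, near the top of a scale of percent remaining, so they also do not show whether that closeness keeps the step on its core small.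

The compounds shown carry only fluoro or methyl at this place, so the outcome with a chloro or methoxy group there stays open. Going by these compounds alone, with only two cores in hand, it also remains open how the change behaves on any further core.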